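The compounds below may be only part of what the source reports. "The series", "measured", "known", "first", "only" and "open" are said of these compounds alone.

Compound 1 `S=C(Nc1cccnc1)NC1CCN(c2cc(Cl)ccn2)CC1` gives 2100 nM in an assay on membranes from brain for binding affinity to Lysophosphatidylserine lipase ABHD12 (Mus musculus), read by fluorescence, with a stated time of 20 min; on this read-out higher numbers stand for weaker inhibition and lower numbers for stronger inhibition. Compound 2 `COc1ccnc(N2CCC(NC(=S)Nc3cccnc3)CC2)c1` gives > 5000 nM in this assay, which is a limit of the assay and not a number.

Compound 2 therefore stands at the limit of > 5000 nM in this assay, at which 1 of the 2 values shown sits: its inhibition was too weak to yield a number, and the shown step an at least 2.3-fold higher number from compound 1 to compound 2 (0.37 log units; beyond the scatter) records the loss that came with the methoxy in place of chloro on an aromatic carbon. Compound 3 `Cc1cnc(N2CCC(NC(=S)Nc3cccnc3)CC2)c(Cl)c1` differs from compound 2 by 3-chloro-5-methylpyridin-2-yl in place of 4-methoxypyridin-2-yl on an amine nitrogen in a ring. Among the measured compounds shown here, this change brings back a chloro on the ring and adds a methyl, so the one measured step that bears on it is the one from compound 1 to compound 2, read in reverse. For the measured compounds named here, a gain beyond the scatter is expected, roughly an at least 2.0-fold lower number from compound 2 to compound 3 (0.30 log units; that floor lies within the scatter), though the methyl has no measured counterpart here. For compound 3 the estimate is 2500 nM, with a range from 900 nM to 8000 nM.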

Compound 3, half-maximal inhibitory concentration: 3100 nM
Compound 3: middle estimate off by 1.2-fold (0.09 log units), on the low side; the range from low to high includes it.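

In this assay, placing 3-chloro-5-methylpyridin-2-yl on the amine nitrogen in a ring gives an at least 1.6-fold lower number from compound 2 to compound 3 (0.20 log units; that floor lies within the scatter). The value of compound 2 is a limit of the assay and not a number, so this step offers only a floor and its true size cannot be read. The step that can be read in full is a 1.5-fold higher number from compound 1 to compound 3 (0.17 log units; within the scatter), so the two chloro-bearing groups cannot be told apart in this assay, and a chloro on this ring is seen with a measurable value in both compounds that carry one.

As far as these compounds go, the chloro and methyl of compound 3 differ from compound 1 together, so their separate shares stay unknown. From the compounds shown here alone, whether a nitrile or a trifluoromethyl in place of the chloro would move the number beyond the scatter, in either direction, also stays open.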